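The source may hold more compounds than are shown below. What is called first, only, known or untested is meant among the compounds shown, and "the series" means these compounds.

In a functional assay on T98G cells (Homo sapiens) for cytotoxicity, read by MTT assay, with a stated time of 48 h (on this read-out higher numbers stand for weaker inhibition and lower numbers for stronger inhibition), compound 1 `C/C(=N\NC(=S)Nc1ccccc1Cl)c1ccccn1` gives 1.1 nM and compound 2 `C/C(=N/NC(=S)Nc1ccccc1I)c1ccccn1` gives 8.09 nM. Compound 2 therefore holds the higher of the two numbers, with a gap beyond the scatter. Compound 3 `C/C(=N/NC(=S)Nc1ccccc1Cl)c1ccccn1` follows from compound 2 through one change: chloro in place of iodo on an aromatic carbon. Among the compounds with values here, no measured step covers this exchange. Within the data shown here, the only guide is the lower number of compound 1 at 1.1 nM, so a moderate fall is expected. The expected change is a 2.3-fold lower number from compound 2 to compound 3 (0.36 log units; beyond the scatter). For compound 3 the estimate is 3.5 nM, with an expected range of 0.9 nM to 12 nM.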

Compound 3, half-maximal inhibitory concentration: 1.1 nM
The estimate for compound 3 lay 3.2-fold (0.50 log units) above the measured number, within the range that was stated.
By their numbers in this assay, from the lowest: compounds 1 and 3 (each within the scatter of the next); then compound 2.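

Within this assay, the exchange on this aromatic carbon can now be read apart from the double bond: chloro in place of iodo gives a 7.4-fold lower number from compound 2 to compound 3 (0.87 log units; beyond the scatter). Compounds 1 and 2 differed in both features, so they could not separate the two. The drawn configuration shows no change at the digits printed from compound 1 to compound 3 (within the scatter), and this pair tests that feature alone: the fact that compounds 1 and 3 differ only in the configuration as drawn

The compounds shown leave open how bromo, fluoro, methyl or an amine would read at this position. They also leave open whether the drawn configuration would again show no separation with iodo in place.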